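The compounds below may be only part of what the source reports. "The series", "measured", "known", "first", "only" and "open" are said of these compounds alone.

Measured so far in an assay for inhibition of Thromboxane-A synthase (Homo sapiens), using microsomes; on this read-out lower numbers stand for stronger inhibition and higher numbers for weaker inhibition:

- compound 1 `O=C(O)CC/C=C\CC1COC(c2ccc(Cl)cc2Cl)OC1c1cccnc1` gives 42 nM
- compound 2 `O=C(O)CC/C=C\CC1COC(c2ccsc2)OC1c1cccnc1` gives 500 nM
- compound 3 `Cc1ccc(C#N)c(OC(C)(C)C2OCC(C/C=C\CCC(=O)O)C(c3cccnc3)O2)c1` gives 50 nM

Compound 3 has the second highest of the three numbers. Its nearest neighbour is compound 1, whose number is lower by an amount within the scatter, so the two cannot be ordered; its furthest is compound 2, whose number is higher by an amount beyond the scatter.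

Compound 4 `CC(C)(C1OCC(C/C=C\CCC(=O)O)C(c2cccnc2)O1)S(=O)(=O)c1ccccc1` is compound 3 with the following change: a group of 9 heavy atoms (6 carbon, 2 oxygen, 1 sulfur; one six-membered aromatic ring of carbon only) in place of a group of 10 heavy atoms (8 carbon, 1 nitrogen, 1 oxygen; one six-membered aromatic ring of carbon only), on a saturated chain carbon bound to two saturated chain carbons and a saturated ring carbon. The aromatic ring is kept, the nitrile and the ether oxygen leave, and phenylsulfonyl enters at the same place.

Within the data shown here, only one measured step exists, a 12-fold higher number from compound 1 to compound 2 (1.08 log units; beyond the scatter). It concerns a different place, a saturated ring carbon, and swaps one aromatic ring for another; it bears on compound 4 only in showing that a change of the group at that end of the shared core can move the number a long way. Among the measured compounds shown here, no measured pair varies the group on the saturated chain carbon that compound 4 changes, so the direction is open. A modest step is expected, a 1.8-fold higher number from compound 3 to compound 4 (0.26 log units; within the scatter), most likely toward a somewhat higher number.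

Compound 4 is estimated at 90 nM, with a range from 25 nM to 350 nM.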

Compound 4, half-maximal inhibitory concentration: 40 nM
Compound 4: the middle estimate sits 2.3-fold (0.35 log units) above what was measured, and the stated range covers the measured number.
By their numbers in this assay, from the lowest: compounds 4, 1 and 3 (each within the scatter of the next); then compound 2.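

In this assay, the change on the saturated chain carbon bound to two saturated chain carbons and a saturated ring carbon gives a 1.3-fold lower number from compound 3 to compound 4 (0.10 log units; within the scatter), so the two groups cannot be ordered at this place. Among these compounds, this is the first measured step at this place, and it shows that the nitrile and the ether oxygen can leave and phenylsulfonyl can enter, with the six-membered aromatic ring kept, without a change beyond the scatter; the earlier step, at a saturated ring carbon, said nothing about this. The data offer no measured account of why the two groups read alike here.

From the compounds shown here alone, both groups at this place carry a six-membered aromatic ring, so it remains open whether the number holds with no such ring, for example with an amine or a cyclohexyl group in its place. Going by these compounds, it also remains open whether a chlorine on the phenyl ring of phenylsulfonyl would move the number, and whether a second linking group, such as an amide, would behave like the ether and the sulfonyl.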